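Trimming the tert-butyl: from compound 3 to compound 4

This account rests on a few compounds, and the source may have more. Where it says the series, first, only, none or still open, it means among the compounds named here.

This small series shares one core and varies only the aryl group on the amide nitrogen. Compound 1 `COc1nc2c(c(=O)n(C)c(=O)n2C)n1CCCC(=O)Nc1cccc(Cl)c1` carries a 3-chlorophenyl group; in an assay on isolated protein for inhibition of high affinity 3',5'-cyclic-AMP phosphodiesterase 7A (Homo sapiens), read by cAMP accumulation, with a stated time of 10 min (on this read-out higher numbers stand for weaker inhibition and lower numbers for stronger inhibition), compound 1 reaches only the limit of > 200000 nM, so no number is known for it. Compound 2 `COc1nc2c(c(=O)n(C)c(=O)n2C)n1CCCC(=O)Nc1ccc(Cl)cc1` carries a 4-chlorophenyl group; in this assay compound 2 likewise stops at the limit of > 200000 nM. The step that the two limits leave unreadable from compound 1 to compound 2 therefore cannot be read. Within the data shown here, compound 3 `COc1nc2c(c(=O)n(C)c(=O)n2C)n1CCCC(=O)Nc1ccc(C(C)(C)C)cc1` carries a 4-(tert-butyl)phenyl group and gives 19800 nM in this assay, the only plain number among the three. The remaining two sit at the limit of > 200000 nM in this assay, at which 2 of the 3 values shown sit. The steps of an at least 10-fold lower number from compound 1 to compound 3 (1.00 log units; beyond the scatter) and an at least 10-fold lower number from compound 2 to compound 3 (1.00 log units; beyond the scatter) both point the same way: the arrival of the tert-butyl group brought the number down.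

Compound 4 `COc1nc2c(c(=O)n(C)c(=O)n2C)n1CCCC(=O)Nc1ccc(C(C)C)cc1` differs from compound 3 by hydrogen in place of methyl on a saturated chain carbon bound to an aromatic carbon and two saturated chain carbons. This removes part of the very group whose arrival lowered the number, so the step is expected to run the other way, though only partly, because an isopropyl group still stands where chloro stood in compound 2 with its > 200000 nM. The step of a 2.3-fold higher number from compound 3 to compound 4 (0.36 log units; beyond the scatter) is therefore expected to be a moderate rise. Compound 4 is expected to give about 45000 nM in this assay, estimated between 15000 nM and 150000 nM.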

Compound 4, half-maximal inhibitory concentration: > 200000 nM
Compound 4 was reported as a limit (the forecaster's own chance of this, stated with the estimate: 20%); middle value at least 4.4-fold (0.64 log units) from the limit.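

The change of one methyl to hydrogen gives an at least 10-fold higher number from compound 3 to compound 4 (1.00 log units; beyond the scatter), a large step for the loss of a single carbon. In this assay, an isopropyl group therefore does not keep the measurable inhibition seen with the tert-butyl group, and among the compounds shown only the 4-(tert-butyl)phenyl group gives a plain number. Compound 4 stands at a limit and not at a number, and it joins compound 1 and compound 2 there, so the steps among these three cannot be read and isopropyl cannot be ranked against chloro: the limit of > 200000 nM in this assay, at which 3 of the 4 values shown sit.

As far as these compounds go, what remains open is whether a group larger than tert-butyl, such as cyclohexyl or trimethylsilyl, would lower the number further than compound 3 does with its 19800 nM, or whether tert-butyl is already the best fit among such groups. From the compounds shown here alone, it is also open how an amine or a carboxylic acid in place of the tert-butyl group would read in this assay, and whether a longer chain leading to the amide would change the picture.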